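Halogen Swap on the Ketone Phenyl of a Chalcone

A few compounds are considered here, and "the series" means these few. Any claim that something is new, unique, unknown or untested is made for them only; others in the source may bear on it.

compound 1 `N=C(N)N/N=C/c1ccc(/C=C/C(=O)c2cccc(Br)c2)cc1`: 49.7%
compound 2 `N=C(N)N/N=C/c1ccc(/C=C/C(=O)c2ccc(Br)cc2)cc1`: 68.9%
compound 3 `N=C(N)N/N=C/c1ccc(/C=C/C(=O)c2ccc(Cl)cc2Cl)cc1`: 92.5%

In a functional assay on the whole organism (Ear) for inhibition, with Mus musculus as the target, with a stated time of 30 min, at a dose of 100 mg/kg by the intraperitoneal route (on this read-out higher numbers stand for more inhibition at the one dose given (going by the name of the read-out) and lower numbers for less inhibition), compound 1 stands lowest of the three measured numbers; the two steps leading away from it are a number 19.2 percentage points higher from compound 1 to compound 2 (beyond the scatter) and a number 42.8 percentage points higher from compound 1 to compound 3 (beyond the scatter), and the third measured step is a number 23.6 percentage points higher from compound 2 to compound 3 (beyond the scatter). Compound 4 `N=C(N)N/N=C/c1ccc(/C=C/C(=O)c2ccccc2F)cc1` differs from compound 1 by 2-fluorophenyl in place of 3-bromophenyl on a carbonyl carbon. Within the data shown here, no measured step carries exactly this change, but both steps away from compound 1 replace 3-bromophenyl with another halogenated phenyl and both raise the read-out, one modestly and one largely. A rise beyond the scatter is therefore expected here too, though its size is uncertain. Compound 4 is expected to give about 62%, within 38% to 85%. This corresponds to an expected step of a number 12.3 percentage points higher from compound 1 to compound 4 (beyond the scatter).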

Compound 4, a percentage reported as inhibition, in the whole organism at one dose (the size of the read-out at that dose, not a potency): 91.7%
Beside the measured number, compound 4's estimate is 29.7 percentage points below it; measured number above the stated range.
By their numbers in this assay, from the lowest: compound 1; then compound 2; then compounds 4 and 3 (each within the scatter of the next).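

In this assay 2-fluorophenyl gives a number 42 percentage points higher from compound 1 to compound 4 (beyond the scatter) and a number 22.8 percentage points higher from compound 2 to compound 4 (beyond the scatter) and stands level with 2,4-dichlorophenyl at a number 0.8 percentage points lower from compound 3 to compound 4 (within the scatter). A single fluorine on this ring thus reaches what two chlorines reach, and among these four compounds the 2-fluorophenyl and 2,4-dichlorophenyl groups both lie beyond the scatter above the two bromophenyl groups, with none going against that. No measured evidence is available to explain this. The compounds shown leave open whether a halogen matters at all, as plain phenyl or methoxyphenyl could show, and whether 2-chlorophenyl or 2-bromophenyl would read like 2-fluorophenyl.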